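Swapping the Trifluoromethyl for a Thiomorpholine Amide

This account rests on a few compounds, and the source may have more. Where it says the series, first, only, none or still open, it means among the compounds named here.

Measured so far:
compound 1 `O=C(CCCCCCc1ccccc1)c1ncc(-c2ncccn2)o1`: 5.3 nM
compound 2 `O=C(CCCCCCc1ccccc1)c1ncc(C(=O)C(F)(F)F)o1`: 4 nM

In an assay (Rattus norvegicus) for inhibition of Fatty-acid amide hydrolase 1 (Homo sapiens) (a higher number here means a weaker inhibitor, a lower number a stronger inhibitor), compound 2 holds the lowest of the two numbers, though its nearest neighbour, compound 1, sits within the scatter of it: the two cannot be told apart. Within the data shown here, the only measured step, a 1.3-fold lower number from compound 1 to compound 2 (0.12 log units; within the scatter), replaces one group on the aromatic carbon of the shared core with another without any change beyond the scatter.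

Compound 3 `O=C(CCCCCCc1ccccc1)c1ncc(C(=O)N2CCSCC2)o1` is not yet measured. It differs from compound 2 by thiomorpholin-4-yl in place of trifluoromethyl on a carbonyl carbon. Among the measured compounds shown here, no measured step changes a group on that carbonyl carbon, so no step bears directly on this change; the step from compound 1 to compound 2 only shows that this end of the molecule accepts two quite different groups at similar values. Compound 3 is therefore expected to give about 15 nM, with a range of 4 nM to 60 nM. That estimate means an expected step of a 3.8-fold higher number from compound 2 to compound 3 (0.57 log units; beyond the scatter), a modest weakening that may or may not exceed the scatter.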

Compound 3, inhibition constant: 10 nM
Compound 3: the middle estimate sits 1.5-fold (0.18 log units) above what was measured; low and high end bracket the measured number.
By their numbers in this assay, from the lowest: compounds 2, 1 and 3 (each within the scatter of the next, the first and the last beyond it).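

Among these compounds, this is the only measured change on the carbonyl carbon itself, and in this assay it goes beyond the scatter, though modestly (a 2.5-fold higher number from compound 2 to compound 3 (0.40 log units; beyond the scatter)). So thiomorpholin-4-yl is accepted on that carbon, but it does not match trifluoromethyl there, whereas the earlier pair of compounds could not be told apart. Compound 3 and compound 1 also cannot be told apart (a 1.9-fold higher number from compound 1 to compound 3 (0.28 log units; within the scatter)), which adds (thiomorpholin-4-yl)carbonyl to the quite different groups this end of the molecule accepts, and no measurement at hand gives a reason for any of these values.

Open, on these data alone, is whether the ring matters at all: a morpholine amide, with oxygen in place of the ring sulfur, or an open-chain dimethylamide could separate the ring from the amide. A carboxylic acid on the same aromatic carbon would show whether this end accepts a much simpler group.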